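This account rests on a few compounds, and the source may have more. Where it says the series, first, only, none or still open, it means among the compounds named here.

Measured so far:
Compound 1 `COC(=O)CC1CCN(C[C@H]2CN(c3ccc(-n4cc(-c5ccccn5)cn4)c(F)c3)C(=O)O2)CC1`. In an ADME assay on L02 cells (Homo sapiens) for cytotoxicity, read by MTT assay, with a stated time of 48 h (on this read-out lower numbers stand for stronger inhibition and higher numbers for weaker inhibition), compound 1 gives > 400 ug/mL, a limit of the assay rather than a number.
Compound 2 `COC[C@H]1CN(c2ccc(-n3cc(-c4ccccn4)cn3)c(F)c2)C(=O)O1`. In this assay compound 2 gives > 400 ug/mL, again a limit.

Compound 1 therefore stands only at a limit on the numbers shown; no measured number places it more precisely. The step from compound 1 to compound 2 cannot be read: a step that the two limits leave unreadable from compound 1 to compound 2. Within the data shown here, both values sit at the same place, (the limit of > 400 ug/mL in this assay, at which 2 of the 2 values shown sit), so no measured step offers a size that could guide a prediction.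

Compound 3 `CCC(=O)NC[C@H]1CN(c2ccc(-n3cc(-c4ccccn4)cn3)c(F)c2)C(=O)O1` has not yet been measured in this assay. Compared with compound 1, the change is propanoylamino in place of 4-((methoxycarbonyl)methyl)piperidin-1-yl on a saturated chain carbon bound to a saturated ring carbon. Among the measured compounds shown here, the only step that bears on it, from compound 1 to compound 2, is unreadable, and both compounds it joins rest at the limit. The expected step from compound 1 to compound 3 is therefore none beyond the scatter: a number no higher from compound 1 to compound 3 (the limit leaves the size open), with compound 3 most likely again reaching the limit. Compound 3 is estimated at 400 ug/mL, in the range 200 ug/mL to 800 ug/mL.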

Compound 3, half-maximal inhibitory concentration: 204 ug/mL
Compound 3: the middle estimate sits 2.0-fold (0.29 log units) above what was measured; measured number inside the range.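

In this assay, among these compounds, compound 3 gives 204 ug/mL, the first actual number in this set. A group on a saturated chain carbon bound to a saturated ring carbon therefore does not always leave the reading at the limit. Propanoylamino in place of 4-((methoxycarbonyl)methyl)piperidin-1-yl gives an at least 1.9-fold lower number from compound 1 to compound 3 (0.29 log units; that floor lies within the scatter), and propanoylamino in place of methoxy gives an at least 1.9-fold lower number from compound 2 to compound 3 (0.29 log units; that floor lies within the scatter). These are floors and not sizes, so the true gaps could be larger, since the other two compounds offer only a limit and no number: the limit of > 400 ug/mL in this assay, at which 2 of the 3 values shown sit.

Going by these compounds, how far compound 1 and compound 2 really lie from compound 3 stays unknown, and the step between those two cannot be read. On these data alone, it also remains open which part of propanoylamino goes with the measured number, something that acetylamino, a longer chain on the carbonyl or a free amine on the same saturated chain carbon could help to separate.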